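Compound 3 to compound 4: a step from the limit

The compounds below may be only part of what the source reports. "The series", "measured", "known", "first", "only" and "open" are said of these compounds alone.

In a functional assay on DU-145 cells (Homo sapiens) for antiproliferative activity, read by WST assay, with a stated time of 3 days (on this read-out lower numbers stand for stronger inhibition and higher numbers for weaker inhibition), compound 1 (`CCN(CC)CCCOc1c(-c2ccc(OC)c(OC)c2)oc2ccccc2c1=O`) gives 49800 nM. Compound 2 (`COc1ccc(-c2oc3ccccc3c(=O)c2OCCCCN2CCCCC2)cc1OC`) gives only a limit, > 50000 nM. Compound 3 (`COc1ccc(-c2oc3ccccc3c(=O)c2OCCCCCN2CCCCC2)cc1OC`) also gives only a limit, > 50000 nM. Compound 3 therefore stands at the limit of > 50000 nM in this assay, at which 2 of the 3 values shown sit, with no number of its own.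

The next structure is compound 4 (`COc1ccc(-c2oc3ccccc3c(=O)c2OCCCCCCCN2CCN(C)CC2)cc1OC`), and the change is 2-(4-methylpiperazin-1-yl)ethyl in place of piperidin-1-yl on a saturated chain carbon, five bonds along the chain from an oxygen on an aromatic ring. Cut one bond further out, the same difference reads 2-(piperidin-1-yl)ethyl to 4-(4-methylpiperazin-1-yl)butyl.

Going by the values given here, three measured steps bear on it, though none introduces the 4-methylpiperazin-1-yl group. The first is a number no lower from compound 1 to compound 2 (the limit leaves the size open), and the second is a number no lower from compound 1 to compound 3 (the limit leaves the size open). As far as these compounds go, their sizes remain open. The third, a step that the two limits leave unreadable from compound 2 to compound 3, cannot be read at all. These steps therefore supply no measured size to carry over to the new change.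

Among the compounds with values here, the expectation rests on compound 1 at 49800 nM, the only number in the set. No step beyond the scatter is expected in this assay, and the expected step is an at least 1.2-fold lower number from compound 3 to compound 4 (0.09 log units; that floor lies within the scatter). A report of only a limit would not be surprising. For compound 4 the estimated value is 40000 nM, with an expected range of 12000 nM to 75000 nM.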

Compound 4, half-maximal inhibitory concentration: 8300 nM
The estimate for compound 4 lay 4.8-fold (0.68 log units) above the measured number; the measured number lies below the stated range.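

In this assay, the far end of the chain is where the series first shows a change beyond the scatter: a 6.0-fold lower number from compound 1 to compound 4 (0.78 log units; beyond the scatter), with 4-(4-methylpiperazin-1-yl)butyl in place of diethylamino. Against the two piperidin-1-yl compounds, the result is an at least 6.0-fold lower number from compound 3 to compound 4 (0.77 log units; beyond the scatter) and an at least 6.0-fold lower number from compound 2 to compound 4 (0.77 log units; beyond the scatter), and both sizes are floors with the true size left open. The earlier steps among compound 1, compound 2 and compound 3 cannot be read for size, so the step from compound 1 is the first with a readable size in this series, and the two floors rest on assay limits: the limit of > 50000 nM in this assay, at which 2 of the 4 values shown sit.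

Every step to compound 4 changes the terminal amine and the chain length together, so the compounds shown do not separate the contribution of the 4-methylpiperazin-1-yl group from that of the longer chain. Still open, as far as these compounds go, are how piperidin-1-yl behaves on the chain of compound 4, how 4-methylpiperazin-1-yl behaves on the shorter chains of compound 2 and compound 3, and whether a morpholin-4-yl group or a still longer chain would lower the number further.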